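A few compounds are considered here, and "the series" means these few. Any claim that something is new, unique, unknown or untested is made for them only; others in the source may bear on it.

Measured so far:
compound 2 `CCCCCCCC(=O)Nc1nc2ccc(NC(=O)c3c(Cl)cccc3Cl)cc2s1`: 0.18 ug/mL
compound 1 `O=C(Nc1ccc2nc(NC(=O)C3CCCCC3)sc2c1)c1cccc(Oc2ccccc2)c1`: a limit, > 4 ug/mL

Going by the values given here, in a functional assay on WI-38 VA13 cells (Homo sapiens) for cytotoxicity (on this read-out lower numbers stand for an effect already at smaller amounts and higher numbers for an effect only at larger amounts of compound), compound 2 supplies the only actual number. For compound 1 the assay reports a limit only, (the limit of > 4 ug/mL in this assay, at which 1 of the 2 values shown sits). Compound 3 `COc1ccccc1Nc1nc2ccc(NC(=O)c3c(Cl)cccc3Cl)cc2s1` differs from compound 2 in a single place: 2-methoxyphenyl in place of heptylcarbonyl on a nitrogen on an aromatic ring. Among the compounds with values here, no measured pair differing in one place exists to calibrate this change, so its size is uncertain. A loss beyond the scatter in this assay is expected, estimated as a 3.3-fold higher number from compound 2 to compound 3 (0.52 log units; beyond the scatter). Compound 3 is therefore expected to give 0.6 ug/mL in this assay, with a range from 0.15 ug/mL to 4 ug/mL.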

Compound 3, half-maximal effective concentration: > 7.2 ug/mL
Compound 3: no number, only a limit; the forecaster's own chance of this, stated with the estimate: 20%; at least 12-fold (1.07 log units) between middle value and limit.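

At the nitrogen on an aromatic ring, replacing heptylcarbonyl with 2-methoxyphenyl gives, in this assay, an at least 40-fold higher number from compound 2 to compound 3 (1.60 log units; beyond the scatter). Going by these compounds alone, this is the first step measured at this place, and it shows that the cytotoxic effect of compound 2 does not withstand this change. The reading for compound 3 is a limit and not a number: the limit of > 7.2 ug/mL in this assay, at which 1 of the 3 values shown sits.

The compounds shown leave open whether the loss goes with removing the carbonyl or with the entering aromatic ring. They also leave open whether a shorter acyl chain such as butanoyl, or an unsubstituted phenyl, would behave differently at this nitrogen.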